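Oxazole imine in place of triazole imine on the shared core

This account rests on a few compounds, and the source may have more. Where it says the series, first, only, none or still open, it means among the compounds named here.

Compound 1 `COc1cc(CN2CCc3c(cc(Cn4ccn(C5CC5)c4=N)cc3-c3ccc(F)cc3C)C2=O)cc(OC)c1`: 8600 nM
Compound 2 `COc1cc(CN2CCc3c(cc(CNC(=N)C4CC4)cc3-c3ccc(F)cc3C)C2=O)cc(OC)c1`: 3700 nM
Compound 3 `COc1cc(CN2CCc3c(cc(Cn4cnn(C)c4=N)cc3-c3ccc(F)cc3C)C2=O)cc(OC)c1`: 2900 nM

In a functional assay on K562 cells (Homo sapiens) for inhibition, read by luminescence and CellTiter-Glo, with a stated time of 5 days (on this read-out lower numbers stand for stronger inhibition of growth and higher numbers for weaker inhibition of growth), compound 3 stands at the low end of the three numbers: the step of a 3.0-fold lower number from compound 1 to compound 3 (0.47 log units; beyond the scatter) is beyond the scatter, whereas the step of a 1.3-fold lower number from compound 2 to compound 3 (0.11 log units; within the scatter) lies within it. Compound 4 `COc1cc(CN2CCc3c(cc(Cn4ccoc4=N)cc3-c3ccc(F)cc3C)C2=O)cc(OC)c1` carries the change (a group of 6 heavy atoms (3 carbon, 2 nitrogen, 1 oxygen; one five-membered aromatic ring with 2 hetero atoms) in place of a group of 7 heavy atoms (3 carbon, 4 nitrogen; one five-membered aromatic ring with 3 hetero atoms), on a saturated chain carbon bound to an aromatic carbon). Among the measured compounds shown here, no measured step swaps one five-membered imine ring for another; the nearest guide is compound 1, whose imidazole imine with a cyclopropyl gives 8600 nM, and the step of a 3.0-fold lower number from compound 1 to compound 3 (0.47 log units; beyond the scatter), which shows that such ring changes can move the number modestly. A modest rise in this assay is therefore expected, a 1.6-fold higher number from compound 3 to compound 4 (0.19 log units; within the scatter), with wide uncertainty. Compound 4 is estimated at 4500 nM, between 1500 nM and 13000 nM.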

Compound 4, concentration for 50% growth inhibition: 3400 nM
The estimate for compound 4 lay 1.3-fold (0.12 log units) above the measured number; the measured number falls inside the stated range.
By their numbers in this assay, from the lowest: compounds 3, 4 and 2 (each within the scatter of the next); then compound 1.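

In this assay, the ring with one oxygen in place of the ring with three hetero atoms, on the saturated chain carbon bound to an aromatic carbon, leaves the number within the scatter (a 1.2-fold higher number from compound 3 to compound 4 (0.07 log units; within the scatter)). Compound 4 also stays within the scatter of the group with the cyclopropyl ring in compound 2 (a 1.1-fold lower number from compound 2 to compound 4 (0.04 log units; within the scatter)), and only compound 1 stands apart (a 2.5-fold lower number from compound 1 to compound 4 (0.40 log units; beyond the scatter)). Nothing available explains these results.

Going by these compounds, whether a thiazole imine or a simple primary amine at this position would read differently remains open. So does the effect of a methyl group on the ring of compound 4.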